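The source may hold more compounds than are shown below. What is called first, only, known or untested is meant among the compounds shown, and "the series" means these compounds.

This piece follows a single structural change within a small set of compounds tested in a functional assay on MT2 cells (Homo sapiens) for cytotoxicity, read by MTT assay; on this read-out higher numbers stand for lower toxicity in this test and lower numbers for higher toxicity in this test. Of the compounds shown here, two have been measured so far. Compound 1 `N#Cc1ccc(Nc2nccs2)cc1OCc1ccco1` gives 18000 nM in this assay. Compound 2 `CC(C)=CCOc1cc(Nc2nccc(C(F)(F)F)n2)ccc1Cl` gives 2500 nM in this assay; of the two numbers this is the lower one, and the gap to compound 1 lies beyond the usual scatter, so compound 2 is the more toxic of the pair in this test.

Compound 3 `COc1ccnc(Nc2ccc(Cl)c(OCC=C(C)C)c2)n1` has not yet been measured. It differs from compound 2 in one place: methoxy in place of trifluoromethyl on an aromatic carbon. Going by the values given here, no measured pair in this set shows what such a swap does to the read-out, so any expectation rests on compound 2 alone and carries wide uncertainty. The swap is expected to move the number only modestly, with a slight lean toward a higher value, meaning somewhat lower toxicity; the expected change is a 1.6-fold higher number from compound 2 to compound 3 (0.20 log units; within the scatter). Compound 3 is therefore expected to give about 4000 nM, with a plausible range from 1500 nM to 12000 nM.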

Compound 3, half-maximal cytotoxic concentration: 9000 nM
Beside the measured number, compound 3's estimate is 2.3-fold (0.35 log units) below it; low and high end bracket the measured number.
By their numbers in this assay, from the lowest: compound 2; then compounds 3 and 1 (each within the scatter of the next).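

On the six-membered aromatic ring with 2 nitrogen, at the aromatic carbon next to the ring nitrogen, methoxy in place of trifluoromethyl gives a 3.6-fold higher number from compound 2 to compound 3 (0.56 log units; beyond the scatter) in this assay. This first single-place comparison shows that the group at this position matters: changing it alone moves the number beyond the usual scatter, toward lower toxicity in this test. The change swaps 4 heavy atoms and 0 hydrogen-bond acceptors for 2 heavy atoms and 1 hydrogen-bond acceptor, but no measurement here separates these differences or shows why the number moved.

Going by these compounds, what an amine, a hydroxyl group, a plain methyl group or a longer ethoxy chain would do on this same carbon remains open, as does whether a bare hydrogen there would give a number closer to that of compound 2 or compound 3. Also open, on these data alone, is whether the same swap would have a similar effect with the other parts of the molecule changed, such as the chlorine or the prenyl-type ether chain, so this one step cannot yet be treated as a general rule.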